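A few compounds are considered here, and "the series" means these few. Any claim that something is new, unique, unknown or untested is made for them only; others in the source may bear on it.

Measured compounds:
- compound 1, `COc1ccc(-c2cc(/C=C/C(=O)c3ccc(N)cc3)[nH]n2)cc1`: -47%
- compound 2, `COc1cc(-c2cc(/C=C/C(=O)c3ccc(N)cc3)[nH]n2)cc(OC)c1OC`: -64%
- compound 3, `COc1cc(-c2cc(/C=C/C(=O)c3ccc(Cl)c(Cl)c3)[nH]n2)cc(OC)c1OC`: 9%

In a functional assay on RXF 393 cells (Homo sapiens) for cytotoxicity, read by sulforhodamine B assay, with a stated time of 48 h, tested at 10 uM (on this read-out higher numbers stand for a weaker effect at the one concentration tested and lower numbers for a stronger effect), compound 2 gives the lowest of the three numbers; compound 1 stands nearest, higher by a margin beyond the scatter, and compound 3 stands furthest. Within the data shown here, the one step recorded within the set, a number 73 percentage points higher from compound 2 to compound 3 (beyond the scatter), concerns the group on the carbonyl carbon and leaves the methoxy-bearing ring untouched, so it does not bear on the change considered here.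

Compound 4, `COc1ccc(-c2cc(/C=C/C(=O)c3ccc(N)cc3)[nH]n2)cc1OC`, is not yet measured. It differs from compound 2 as follows: hydrogen in place of methoxy on an aromatic carbon. Among the measured compounds shown here, no measured step covers the loss of a single methoxy from this ring. Compounds 1 and 2 differ by two methoxy groups, not one, and their values bracket what a single removal might give: the number for compound 1 is higher than that for compound 2 by more than the scatter. Taking compound 4 as intermediate in substitution, a small rise from compound 2, somewhere between the numbers of compound 2 and compound 1, is expected, possibly not beyond the scatter.

The estimate for compound 4 in this assay is -55%, within -75% to -35%, which means an expected step of a number 9 percentage points higher from compound 2 to compound 4 (within the scatter).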

Compound 4, a percentage reported as activity, at one concentration (the size of the read-out at that concentration, not a potency): -39%
Compound 4: middle estimate off by 16 percentage points, on the low side; low and high end bracket the measured number.
By their numbers in this assay, from the lowest: compound 2; then compounds 1 and 4 (each within the scatter of the next); then compound 3.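

In this assay, the methoxy on the aromatic carbon ortho to a methoxy group and meta to a large group now has a measured contribution of its own: replacing it with hydrogen gives (a number 25 percentage points higher from compound 2 to compound 4 (beyond the scatter)), a single-group change that the two-methoxy difference between compound 1 and compound 2 could not isolate. The other single-methoxy comparison reads differently, since methoxy in place of hydrogen on an aromatic carbon of compound 1 gives (a number 8 percentage points higher from compound 1 to compound 4 (within the scatter)), so within these three compounds a methoxy step beyond the scatter appears only on going to the full trimethoxy pattern of compound 2, and the two steps are not equal in size. Nothing measured here accounts for that difference between the two steps.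

From the compounds shown here alone, what a hydroxyl, an ethoxy or a fluorine would give at this position remains open. Also open, going by these compounds, is whether this methoxy counts for as much when 3,4-dichlorophenyl stands on the carbonyl carbon, as in compound 3, since the single-methoxy steps are read only with 4-aminophenyl in that place.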